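Cyclohexyl urea series: cytotoxicity notes on compound 3

This account rests on a few compounds, and the source may have more. Where it says the series, first, only, none or still open, it means among the compounds named here.

Measured so far in an ADME assay on HEL cells (Homo sapiens) for cytotoxicity; on this read-out higher numbers stand for lower toxicity in this test and lower numbers for higher toxicity in this test:
compound 1, `COc1cc(NC(C)CCCNC(=O)NC2CCCCC2)c2ncccc2c1`, gives 100000 nM.
compound 2, `COc1cc(NC(C)CCCNC(=O)NC2CCCC2)c2ncccc2c1`, gives 100000 nM.

Compound 1 stands level with compound 2 at the digits shown; its nearest neighbour in the set is compound 2, and the step of no change at the digits printed from compound 1 to compound 2 (within the scatter), cyclopentyl in place of cyclohexyl on an amide-type nitrogen, left the read-out unchanged within the scatter.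

Compound 3, `COc1cc(NC(C)CCCNC(=O)N(C2CCCCC2)C2CCCCC2)c2ncccc2c1`, is to be measured in this assay. Relative to compound 1 the change is cyclohexyl in place of hydrogen on an amide-type nitrogen. Among the measured compounds shown here, no measured step puts a second group on that nitrogen; the only step available, no change at the digits printed from compound 1 to compound 2 (within the scatter), varies the ring size on the same nitrogen and was flat. Both measured compounds sit at the same figure, so there is no trend to extrapolate, and a step of no size beyond the scatter is expected, no change at the digits printed from compound 1 to compound 3 (within the scatter). Because compound 1 gives 100000 nM, compound 3 is estimated at 100000 nM, with a range from 30000 nM to 100000 nM.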

Compound 3, minimum cytotoxic concentration: 4000 nM
Beside the measured number, compound 3's estimate is 25-fold (1.40 log units) above it; the measured number lies below the stated range.
By their numbers in this assay, from the lowest: compound 3; then compounds 1 and 2 (each within the scatter of the next).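

In this assay, the amide-type nitrogen carrying the saturated ring responds strongly to a second substituent: cyclohexyl in place of hydrogen gives a 25-fold lower number from compound 1 to compound 3 (1.40 log units; beyond the scatter) and places compound 3 on the more toxic side in this test. The earlier pair, with no change at the digits printed from compound 1 to compound 2 (within the scatter) as the ring size changed, did not reveal this sensitivity, so a flat result for changing the ring does not extend to replacing the amide hydrogen at the same nitrogen. No supporting measurement bears on why the number falls.

The compounds shown leave open whether any second group on that nitrogen lowers the number or whether the drop is tied to cyclohexyl, and a methyl group there would separate those two readings. Also open, as far as these compounds go, is whether an amine or a carboxylic acid on the added ring would keep the number of compound 3 or return it towards that of compound 1.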